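Replacing Cyclopropyl with Cyclohexyl on the Amine Nitrogen

The source may report more compounds than this note shows. Statements on the series, on what has been measured and on what is new or still open speak of the compounds shown alone.

Compound 1 `O=c1cc(NC2CC2)cc(-c2ccccc2)o1`: in a functional assay on A549 cells (Homo sapiens) for cytotoxicity, read by MTT assay, with a stated time of 72 h (a lower number here means that less compound is needed, a higher number that more compound is needed for the effect), compound 1 gives > 30 uM, which is a limit of the assay rather than a number.
Compound 2 `CCCCCc1cc(Nc2ccc(OC)cc2)cc(=O)o1`: in this assay compound 2 gives 4.42 uM.
Compound 3 `COc1ccc(Nc2cc(-c3ccc4ccccc4c3)oc(=O)c2)cc1`: in this assay compound 3 gives 0.15 uM.

Compound 1 therefore stands at the limit of > 30 uM in this assay, at which 1 of the 3 values shown sits, with no measured number of its own. Within the data shown here, compound 2 and compound 3 differ from compound 1 in more than one place, so no single change connects them, and no measured step exists for the change considered here. Compound 4 `O=c1cc(NC2CCCCC2)cc(-c2ccccc2)o1` differs from compound 1 by cyclohexyl in place of cyclopropyl on a nitrogen on an aromatic ring. With only a limit for compound 1, the expected step is hard to size; compound 4 is expected to move from compound 1 by an at least 1.5-fold lower number from compound 1 to compound 4 (0.17 log units; that floor lies within the scatter), likely little beyond the scatter. In this assay compound 4 is estimated at 20 uM, between 5 uM and 60 uM.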

Compound 4, concentration for half-maximal effect: 9.69 uM
The estimate for compound 4 lay 2.1-fold (0.31 log units) above the measured number, and the stated range covers the measured number.
By their numbers in this assay, from the lowest: compound 3; then compound 2; then compound 4. At a limit, above all of these: compound 1.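

Among these compounds, on the amine nitrogen of the shared core, the change from cyclopropyl to cyclohexyl gives the first step at this position in this assay, and it lies beyond the scatter: an at least 3.0-fold lower number from compound 1 to compound 4 (0.49 log units; beyond the scatter). Compound 1 has only a limit, so this step is a minimum and its full size cannot be read: the limit of > 30 uM in this assay, at which 1 of the 4 values shown sits. Among the compounds shown here, compound 4 gives this nitrogen substituent a measured number for the first time.

Going by these compounds, it remains open whether the lower number follows the ring or simply the carbon count. A cyclopentyl group or an open hexyl chain on the same nitrogen could help separate the two.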